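From 4-cyanophenyl to 3,4,5-trimethoxyphenyl on compound 2

The source may report more compounds than this note shows. Statements on the series, on what has been measured and on what is new or still open speak of the compounds shown alone.

In a functional assay on HepG2 cells (Homo sapiens) for cytotoxicity, read by MTT assay, with a stated time of 24 h (a higher number here means a weaker inhibitor, a lower number a stronger inhibitor), compound 2 `N#Cc1ccc(/C=C2\CN(S(=O)(=O)c3ccc(F)cc3)C/C(=C\c3ccccc3F)C2=O)cc1` gives 8180 nM and lies within the scatter of compound 1 `O=C1/C(=C/c2ccccc2F)CN(S(=O)(=O)c2ccc(F)cc2)C/C1=C\c1ccccc1F` at 7220 nM in this pair. Compound 3 `COc1cc(/C=C2\CN(S(=O)(=O)c3ccc(F)cc3)C/C(=C\c3ccccc3F)C2=O)cc(OC)c1OC` has 3,4,5-trimethoxyphenyl in place of 4-cyanophenyl on a double-bonded chain carbon bound to a double-bonded ring carbon in all. For the measured compounds named here, the one measured step at this place, a 1.1-fold higher number from compound 1 to compound 2 (0.05 log units; within the scatter) in size, stayed within the scatter. No step beyond the scatter is therefore expected in this assay although a single step is slim evidence. The estimated step is a 1.2-fold lower number from compound 2 to compound 3 (0.07 log units; within the scatter) in size. Compound 3 is expected at 7000 nM with an estimated range from 2500 nM to 16000 nM overall.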

Compound 3, half-maximal inhibitory concentration: 7940 nM
The estimate for compound 3 lay 1.1-fold (0.05 log units) below the measured number; the measured number falls inside the stated range.
By their numbers in this assay, from the lowest: compounds 1, 3 and 2 (each within the scatter of the next).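

In this assay, replacing 4-cyanophenyl with 3,4,5-trimethoxyphenyl on a double-bonded chain carbon bound to a double-bonded ring carbon leaves the number within the scatter (a 1.0-fold lower number from compound 2 to compound 3 (0.01 log units; within the scatter)), and the same holds for replacing 2-fluorophenyl (a 1.1-fold higher number from compound 1 to compound 3 (0.04 log units; within the scatter)). This position has now taken three differently substituted phenyl groups, including one with three methoxy groups, with no step beyond the scatter. Nothing given here explains this flat result. Still open, going by these compounds, is whether a group other than a substituted phenyl, such as an amine, a carboxylic acid or a longer alkyl chain, would move the number at this position.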